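Para-fluoro on the styryl ring of an acetoxymethyl enone

The source may report more compounds than this note shows. Statements on the series, on what has been measured and on what is new or still open speak of the compounds shown alone.

Two members of the series have numbers in a functional assay on WiDr cells (Homo sapiens) for inhibition, read by sulforhodamine B assay, with a stated time of 48 h; a higher number here means a weaker inhibitor of growth, a lower number a stronger inhibitor of growth. Compound 1 `CC(=O)OC/C(=C\C1CCCCC1)C(=O)c1ccccc1` gives 21000 nM. Compound 2 `CC(=O)OC/C(=C\c1ccccc1)C(=O)c1ccccc1` gives 17000 nM. Going by the values given here, the single step between them, a 1.2-fold lower number from compound 1 to compound 2 (0.09 log units; within the scatter), is a change of phenyl in place of cyclohexyl on a double-bonded chain carbon bound to a double-bonded chain carbon; the two numbers therefore cannot be told apart, and compound 2 is treated here as equivalent to compound 1 rather than as better or worse.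

Compound 3 `CC(=O)OC/C(=C\c1ccc(F)cc1)C(=O)c1ccccc1` is the next step from compound 2. Its difference is fluoro in place of hydrogen on an aromatic carbon, a fluoro in place of hydrogen on an aromatic carbon of a six-membered aromatic ring of carbon only, para to a large group; read one bond further out, phenyl becomes 4-fluorophenyl.

Among the compounds with values here, no measured step in this assay touches the aromatic ring itself, so none bears directly on this change. Within the data shown here, the one step available, a 1.2-fold lower number from compound 1 to compound 2 (0.09 log units; within the scatter), shows that a large swap at this position left the number within the scatter, which argues for no step beyond the scatter here either. Compound 3 is therefore expected at 15000 nM, in the range 6000 nM to 40000 nM, meaning an estimated step of a 1.1-fold lower number from compound 2 to compound 3 (0.05 log units; within the scatter).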

Compound 3, concentration for 50% growth inhibition: 13000 nM
Compound 3: middle estimate off by 1.2-fold (0.06 log units), on the high side; the range from low to high includes it.
By their numbers in this assay, from the lowest: compounds 3, 2 and 1 (each within the scatter of the next).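

In this assay the first change made on the aromatic ring itself gives a 1.3-fold lower number from compound 2 to compound 3 (0.12 log units; within the scatter), so fluoro in place of hydrogen on this aromatic carbon, para to a large group, cannot be told apart from the unsubstituted phenyl of compound 2. The wider comparison on the same chain carbon gives a 1.6-fold lower number from compound 1 to compound 3 (0.21 log units; within the scatter), which means that even with the ring fluorinated and set against the cyclohexyl of compound 1, the swap stays inside the scatter and all three compounds sit at one level, with no readable preference yet for any of these groups at this position. No accompanying measurement bears on this result.

Whether any group at this ring place can move the number beyond the scatter remains open, since a single fluorine is the only substituent shown there, and a methoxy, a nitro or a dimethylamino group would test the point more severely. The compounds shown also leave open how the number responds to changes elsewhere on the shared core, such as a free hydroxyl or an amine in place of the acetate.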